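The source may report more compounds than this note shows. Statements on the series, on what has been measured and on what is new or still open speak of the compounds shown alone.

Compound 3 `COc1ccc2[nH]c(C(=O)N3CC(=O)N(Cc4ccccc4)[C@@H](CN4CC5CCCCC5C4)C3)cc2c1` is the reference here. In an ADME assay on Vero cells (Chlorocebus sabaeus) for cytotoxicity, with a stated time of 7 days (a higher number here means that more compound is tolerated, a lower number that less compound is tolerated), compound 3 gives 8200 nM, the highest of the two plain numbers in this set. Compound 1 `COc1ccc2[nH]c(C(=O)N3CC(=O)N(Cc4ccccc4)[C@@H](N4[C@H](C)CCC[C@@H]4C)C3)cc2c1` gives 1400 nM. Compound 2 `COc1ccc2[nH]c(C(=O)N3CC(=O)N(Cc4ccccc4)[C@@H](CN4CCN(c5ccccn5)CC4)C3)cc2c1` reaches only a limit of the assay, > 30000 nM. The two measured steps onto compound 3 are a 5.9-fold higher number from compound 1 to compound 3 (0.77 log units; beyond the scatter) and an at least 3.6-fold lower number from compound 2 to compound 3 (0.56 log units; beyond the scatter). The change to compound 4 `COc1ccc2[nH]c(C(=O)N3CC(=O)N(Cc4ccccc4)[C@@H](CN4CCn5cccc5C4)C3)cc2c1` is a group of 9 heavy atoms (7 carbon, 2 nitrogen; one five-membered aromatic ring with 1 hetero atom, one six-membered non-aromatic ring with 2 hetero atoms) in place of a group of 9 heavy atoms (8 carbon, 1 nitrogen; one five-membered non-aromatic ring with 1 hetero atom, one six-membered non-aromatic ring of carbon only), on a saturated chain carbon bound to a saturated ring carbon. The entering group again carries two nitrogens and an aromatic ring, as in compound 2, whose value was a limit; this points toward a higher number, but the step from compound 2 to compound 3 was itself only a limit, so the size is uncertain. Compound 4 is expected to give 15000 nM, within 5000 nM to 30000 nM. The expected step is a 1.8-fold higher number from compound 3 to compound 4 (0.26 log units; within the scatter).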

Compound 4, half-maximal cytotoxic concentration: > 100000 nM
Compound 4 was reported as a limit (the forecaster's own chance of this, stated with the estimate: 30%); at least 6.6-fold (0.82 log units) between middle value and limit.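

At this saturated chain carbon bound to a saturated ring carbon, the change of group has a large effect in this assay: the entering group, with its five-membered aromatic ring, gives an at least 12-fold higher number from compound 3 to compound 4 (1.08 log units; beyond the scatter), and the comparison with the group on the saturated ring carbon gives an at least 71-fold higher number from compound 1 to compound 4 (1.85 log units; beyond the scatter). These steps are minimum sizes, and compound 4 is a limit, not a number: the limit of > 100000 nM in this assay, at which 1 of the 4 values shown sits.

As far as these compounds go, the step between compound 2 and compound 4 cannot be read, and how far compound 4 lies past its limit remains unknown. From the compounds shown here alone, whether the rise needs the five-membered aromatic ring also stays open, and a morpholine at the same place could speak to that.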